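Benzyl in Place of Tert-Butyl on the Ring Nitrogen

A few compounds are considered here, and "the series" means these few. Any claim that something is new, unique, unknown or untested is made for them only; others in the source may bear on it.

Compound 1 `Cc1nn(C(C)(C)C)c2nc(C3CC3)c(/C=C/[C@@H](O)C[C@@H](O)CC(=O)O)c(-c3ccc(F)cc3)c12` gives 4.5% in an in vivo functional assay on the whole organism for inhibition of 3-hydroxy-3-methylglutaryl-coenzyme A reductase (Rattus norvegicus), at a dose of 0.2 mg/kg by the oral route; a lower number here means a weaker effect, a higher number a stronger effect of the compound at the dose given. Compound 2 `Cc1nn(C(C)(C)C)c2nc(C(C)C)c(/C=C/[C@@H](O)C[C@@H](O)CC(=O)O)c(-c3ccc(F)cc3)c12` gives 51.8%. Compound 3 `O=C(O)C[C@H](O)C[C@H](O)/C=C/c1c(C2CC2)nc2sccc2c1-c1ccc(F)cc1` gives 38.1%.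

Compound 2 stands highest of the three, with compound 3 nearest and compound 1 furthest. Among the compounds with values here, the one measured step, a number 47.3 percentage points higher from compound 1 to compound 2 (beyond the scatter), is large but concerns the group on an aromatic carbon, not the ring nitrogen.

Compound 4 `Cc1nn(Cc2ccccc2)c2nc(C(C)C)c(/C=C/[C@@H](O)C[C@@H](O)CC(=O)O)c(-c3ccc(F)cc3)c12` differs from compound 2 by benzyl in place of tert-butyl on an aromatic nitrogen. Within the data shown here, no measured step touches this position, so no direction can be read from the data. The expected step is a number 9.8 percentage points lower from compound 2 to compound 4 (within the scatter), small with wide uncertainty. Compound 4 is therefore estimated at 42%, within 12% to 68%.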

Compound 4, a percentage reported as inhibition, in the whole organism at one dose (the size of the read-out at that dose, not a potency): 16.4%
Compound 4: middle estimate off by 25.6 percentage points, on the high side; the range from low to high includes it.
By their numbers in this assay, from the lowest: compound 1; then compound 4; then compound 3; then compound 2.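

In this assay, the group on this aromatic nitrogen proves to matter: benzyl in place of tert-butyl gives a number 35.4 percentage points lower from compound 2 to compound 4 (beyond the scatter) with the isopropyl group unchanged. Within the data shown here, this is the first measured change at this position, and it shows that a group with a six-membered aromatic ring is tolerated far less well here than tert-butyl. No measurement at hand explains this drop. As far as these compounds go, whether cyclohexyl, a ring of carbon that is not aromatic, or a straight butyl chain on this nitrogen would keep the effect of compound 2 remains open.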